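Trading the amine-bearing chain for a hydroxyethyl tail

The source may hold more compounds than are shown below. What is called first, only, known or untested is meant among the compounds shown, and "the series" means these compounds.

Values from a functional assay on HCT-116 cells (Homo sapiens) for cytotoxicity, read by MTT assay, with a stated time of 72 h; a higher number here means a weaker inhibitor, a lower number a stronger inhibitor:

Compound 1 `O=C(NCc1ccc(F)cc1)c1nc(Br)c2cccnc2c1NCCCNc1c(C(=O)NCc2ccc(F)cc2)nc(Br)c2cccnc12`: a limit of the assay, > 20000 nM.
Compound 2 `CNCCCNc1c(C(=O)NCc2ccc(F)cc2)nc(Br)c2cccnc12`: 9000 nM.
Compound 3 `COc1ccc(CNC(=O)c2nc(Br)c3cccnc3c2N[C@H]2CC[C@H](N)CC2)cc1`: 3000 nM.

Among the two numbers given, compound 2 stands at the higher one; compound 3 gives a lower number, and the gap between them lies beyond the usual scatter. Compound 1 reports only a limit and no number, as noted with the limit of > 20000 nM in this assay, at which 1 of the 3 values shown sits.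

Compound 4 `O=C(NCc1ccc(F)cc1)c1nc(Br)c2cccnc2c1NCCO` has not yet been run in this assay . It differs from compound 2 at one place: hydroxy in place of (methylamino)methyl on a saturated chain carbon, two bonds along the chain from a nitrogen on an aromatic ring. Read one bond further out, the change is 3-(methylamino)propyl to 2-hydroxyethyl.

For the measured compounds named here, no measured pair in this set isolates that change, so the direction rests on compound 2 alone. The step from compound 2 to compound 4 is expected to be an increase in the number, a 1.8-fold higher number from compound 2 to compound 4 (0.25 log units; within the scatter), of a size that could reach beyond the scatter.

Compound 4 is therefore estimated at 16000 nM, with a range from 5000 nM to 40000 nM.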

Compound 4, half-maximal inhibitory concentration: > 20000 nM
Compound 4: a limit, no number; the forecaster's own chance of this, stated with the estimate: 35%; middle value at least 1.2-fold (0.09 log units) away from the limit.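

In this assay compound 4 gives > 20000 nM, which is a limit of the assay and not a number. Hydroxy in place of (methylamino)methyl on this saturated chain carbon is the only change at this position that can be read here, and it gives an at least 2.2-fold higher number from compound 2 to compound 4 (0.34 log units; beyond the scatter), so moving from the 3-(methylamino)propyl chain to the 2-hydroxyethyl chain weakens the read-out beyond the scatter. That limit is not alone in this set: the limit of > 20000 nM in this assay, at which 2 of the 4 values shown sit.

As far as these compounds go, the full size of the step stays open, as does whether it follows from the change of end group or from the shorter chain. A 3-hydroxypropyl chain or a 2-(methylamino)ethyl chain would separate those two changes.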